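A Hydroxyethoxyphenyl Group Replaces a Branched Alkyl Chain

The source may hold more compounds than are shown below. What is called first, only, known or untested is meant among the compounds shown, and "the series" means these compounds.

Of the compounds shown here, two have been measured in an ADME assay on the whole organism (serum, Rattus norvegicus) for protein binding (a lower number here means a smaller unbound share, a higher number a larger unbound share of the compound), so far. Compound 1 `CNC(=O)c1ccc(C(=O)C2=C(O)C(=O)N(c3ccc(-c4ccon4)cc3)C2C2CCCCC2)cc1` gives 0.007. Compound 2 `CCC(CC)C1C(C(=O)c2ccc(OC)cc2)=C(O)C(=O)N1c1ccc(-c2ccon2)cc1` gives 0.0002, the lowest of the two numbers, and its gap to compound 1 lies beyond the scatter. Compound 3 `COc1ccc(C(=O)C2=C(O)C(=O)N(c3ccc(-c4ccon4)cc3)C2c2ccccc2OCCO)cc1` is not yet measured; it differs from compound 2 in one place: 2-(2-hydroxyethoxy)phenyl in place of pentan-3-yl on a saturated ring carbon. Within the data shown here, no step between measured compounds matches this change, so the expectation rests on the two numbers alone. The change is expected to raise the unbound fraction, as a step of a 10-fold higher number from compound 2 to compound 3 (1.00 log units; beyond the scatter). Compound 3 is estimated at 0.002, within 0.0005 to 0.008.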

Compound 3, unbound fraction: 0.003
Beside the measured number, compound 3's estimate is 1.5-fold (0.18 log units) below it; low and high end bracket the measured number.
By their numbers in this assay, from the lowest: compound 2; then compound 3; then compound 1.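

Putting 2-(2-hydroxyethoxy)phenyl in place of pentan-3-yl on the saturated ring carbon gives a 15-fold higher number from compound 2 to compound 3 (1.18 log units; beyond the scatter) in this assay. This position therefore has a clear bearing on the unbound share, at least for this one pair. Nothing measured here says why the number rises.

From the compounds shown here alone, the change adds an aromatic ring and a hydroxyethoxy chain together, so it remains open which of the two carries the step. Also open, going by these compounds, is what a plain phenyl group, or an amine at the end of the chain, would give on this carbon.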